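One ring stereocentre inverted after a mirror-image pair

The compounds below may be only part of what the source reports. "The series", "measured", "known", "first", "only" and "open" are said of these compounds alone.

- compound 1 `CCCCC[C@@H](C[C@@H](O)C[C@H]1CC=CC(=O)O1)OC`: 25200 nM
- compound 2 `CCCCC[C@H](C[C@H](O)C[C@@H]1CC=CC(=O)O1)OC`: 30000 nM

Both values come from a functional assay on A2780 ADR cells (Homo sapiens) for cytotoxicity, read by MTT assay, with a stated time of 24 h; a lower number here means a stronger inhibitor, a higher number a weaker inhibitor. Within the data shown here, compound 2 cannot be told apart from the only other measured compound, as the record shows a 1.2-fold higher number from compound 1 to compound 2 (0.08 log units; within the scatter). These two are mirror images, and the comparison rests on (the fact that compounds 1 and 2 differ only in the configuration as drawn).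

Compound 3 `CCCCC[C@H](C[C@H](O)C[C@H]1CC=CC(=O)O1)OC` is the next to be measured. Its difference from compound 2 is small on paper: the two compounds have the same atoms and bonds and differ only in configuration as drawn: 1 of 3 stereo elements differ; a stereocentre at a saturated ring carbon is drawn S in compound 2 and R in compound 3. Nothing leaves and nothing enters. Among the measured compounds shown here, only one measured step bears on this change, and it is not the same kind of change, since there all stereocentres were inverted and here just one is. Compound 3 is therefore no mirror image of compound 2, and no direct measure of a single inversion exists yet. Since inverting every centre gave only a 1.2-fold higher number from compound 1 to compound 2 (0.08 log units; within the scatter), no step beyond the scatter is expected in this assay. The expected result is a 1.1-fold lower number from compound 2 to compound 3 (0.03 log units; within the scatter). For compound 3 the estimated value is 28000 nM, with an expected range from 12000 nM to 65000 nM.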

Compound 3, half-maximal inhibitory concentration: 57500 nM
For compound 3 the middle estimate is 2.1-fold (0.31 log units) below the measured one; measured number inside the range.
By their numbers in this assay, from the lowest: compounds 1, 2 and 3 (each within the scatter of the next, the first and the last beyond it).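

Among these compounds, the inversion at the saturated ring carbon is the first reading of a single stereocentre in this assay, and with a 1.9-fold higher number from compound 2 to compound 3 (0.28 log units; within the scatter), this change alone does not separate the two compounds. Among the compounds shown here, compounds 1 and 3 keep that ring carbon as drawn and differ at the two saturated chain carbons, and they do separate, though only modestly, with a 2.3-fold higher number from compound 1 to compound 3 (0.36 log units; beyond the scatter), the first step here to pass beyond the scatter. Among these three compounds, then, a change of configuration alone can shift the number, and the comparison rests on one kind of difference: the fact that compounds 1 and 3 differ only in the configuration as drawn

On these data alone, the two chain centres change together in this pair, and which of them carries the step, or whether both are needed, stays open. Also open, as far as these compounds go, is how the number would respond to a different group on the shared core, such as an amine in place of the hydroxyl group or a longer chain.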